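A few compounds are considered here, and "the series" means these few. Any claim that something is new, unique, unknown or untested is made for them only; others in the source may bear on it.

Compound 1, with the structure `O=C(COCc1ccccc1)N1CCN(c2cccc(Cl)c2)CC1`, and compound 2, with the structure `O=C(COCc1cnccn1)N1CCN(c2ccc(Cl)cc2Cl)CC1`, share a core that carries an amide on one side and a chlorinated phenyl ring on the other. Both were tested in a functional assay on HEK293 cells for positive allosteric modulation of metabotropic glutamate receptor 5 (Homo sapiens), read by FLIPR and calcium flux; a higher number here means that more compound is needed for the effect, a lower number that less compound is needed. In this assay compound 1 gives 6700 nM, and compound 2 gives 5200 nM; these two numbers lie within the usual scatter of each other, so neither compound can be set apart from the other on this evidence.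

Compound 3, with the structure `O=C(CCCc1ccncc1)N1CCN(c2ccc(Cl)cc2Cl)CC1`, has not yet been measured. It differs from compound 2 in one place: 2-(pyridin-4-yl)ethyl in place of (pyrazin-2-yl)methoxy on a saturated chain carbon bound to a carbonyl carbon. The chain grows by a carbon, the ring loses one nitrogen, and the oxygen link disappears. Among the compounds with values here, no measured pair shows what such a change does here, so the step from compound 2 to compound 3 is expected to stay within the scatter, and my estimate for compound 3 is 5000 nM, with a range from 1500 nM to 15000 nM. The step this estimate implies is a 1.0-fold lower number from compound 2 to compound 3 (0.02 log units; within the scatter), which is expected rather than known.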

Compound 3, half-maximal effective concentration: 5300 nM
Estimate against measurement, compound 3: 1.1-fold (0.03 log units) below, within the range that was stated.
By their numbers in this assay, from the lowest: compounds 2, 3 and 1 (each within the scatter of the next).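

In this assay the step of a 1.0-fold higher number from compound 2 to compound 3 (0.01 log units; within the scatter) comes from putting 2-(pyridin-4-yl)ethyl in place of (pyrazin-2-yl)methoxy on a saturated chain carbon bound to a carbonyl carbon. So at this place on the chain, the oxygen link and one ring nitrogen can both go, with fewer hydrogen-bond acceptors as a result, and the number shows no readable difference. No other measurement here helps to explain why the number holds.

As far as these compounds go, both changes come together in one step, so it remains open what each would do alone. Also open, from the compounds shown here alone, is what a group of another kind at this place, such as a carboxylic acid or an amine in place of the aromatic ring, would do to the number.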